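The source may hold more compounds than are shown below. What is called first, only, known or untested is meant among the compounds shown, and "the series" means these compounds.

Measured so far in an ADME assay for metabolic stability, with a stated time of 1.5 h, at pH 1.2; a higher number here means that more of the compound is left, a lower number that less of the compound is left:
- compound 1 `CC(=O)NC[C@H]1CN(c2ccc(-c3ccc(/C=N/N4CCN(C)CC4)nc3)c(F)c2)C(=O)O1`: 96.2%
- compound 2 `CC(=O)NC[C@H]1CN(c2ccc(-c3ccc(/C=N/N4CCN(C)CC4)c(O)c3)c(F)c2)C(=O)O1`: 12.2%

Of these two compounds, compound 2 stands lower at 12.2%, and its gap to compound 1 lies beyond the scatter.

The next compound to be measured is compound 3 `CC(=O)NC[C@H]1CN(c2ccc(-c3ccc(/C=N/N4CCSCC4)c(O)c3)c(F)c2)C(=O)O1`. It has thiomorpholin-4-yl in place of the 4-methylpiperazin-1-yl of compound 2, on a double-bonded nitrogen: thiomorpholin-4-yl in place of 4-methylpiperazin-1-yl on a double-bonded nitrogen.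

Both measured compounds carry 4-methylpiperazin-1-yl. Among the measured compounds shown here, the series therefore holds no measured step for a change at this place, and any expectation here is weakly grounded.

In this assay, no step beyond the scatter is expected, with a slight upward lean and a wide margin of doubt. The estimated step is a number 5.8 percentage points higher from compound 2 to compound 3 (within the scatter).

Compound 3 is expected at 18%, with an estimated range of 5% to 45%.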

Compound 3, percent of the compound remaining: 82.9%
Beside the measured number, compound 3's estimate is 64.9 percentage points below it, outside the stated range (above it).
By their numbers in this assay, from the lowest: compound 2; then compound 3; then compound 1.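

In this assay, thiomorpholin-4-yl in place of 4-methylpiperazin-1-yl on a double-bonded nitrogen gives a number 70.7 percentage points higher from compound 2 to compound 3 (beyond the scatter). Among the compounds shown here, the earlier compounds both carried 4-methylpiperazin-1-yl, so this is the first sign that the group at this place, with the rest of compound 2 unchanged, can strongly alter how much compound remains. No measurement in hand accounts for the size or direction of this step.

Still open, on these data alone, is whether the step tracks the entry of the ring sulfur or the loss of the methyl-bearing ring nitrogen; morpholin-4-yl or unsubstituted piperazin-1-yl at this place would help separate the two. Also open, as far as these compounds go, is whether the same change carries over to the core of compound 1.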